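Notes on compound 4: hydroxycarbamoyl replacing imidazolyl

The source may report more compounds than this note shows. Statements on the series, on what has been measured and on what is new or still open speak of the compounds shown alone.

Compound 3 `N#Cc1c(N)nc(SCc2ncc[nH]2)c(C#N)c1-c1ccc(OCC2CC2)cc1` gives 235 nM in an assay on CHO cells for displacement of a labelled ligand from adenosine receptor A1 (Homo sapiens), read by scintillation counting, with a stated time of 90 min (a higher number here means a weaker inhibitor, a lower number a stronger inhibitor), the second highest of the three numbers shown. Compound 1 `N#Cc1c(N)nc(SCc2ncn[nH]2)c(C#N)c1-c1ccc(OCC2CC2)cc1` gives 338 nM, and the step of a 1.4-fold lower number from compound 1 to compound 3 (0.16 log units; within the scatter) stays within the scatter. Compound 2 `CCOc1ccc(-c2c(C#N)c(N)nc(SCc3ncc[nH]3)c2C#N)cc1` gives 8.2 nM; the step of a 29-fold higher number from compound 2 to compound 3 (1.46 log units; beyond the scatter) is large but concerns the group on the oxygen, not the chain at the sulfur. Compound 4 `N#Cc1c(N)nc(SCC(=O)NO)c(C#N)c1-c1ccc(OCC2CC2)cc1` differs from compound 3 thus: hydroxycarbamoyl in place of 1H-imidazol-2-yl on a saturated chain carbon bound to a sulfur. Among the measured compounds shown here, no measured step covers the loss of the five-membered aromatic ring at this place; the only step there, a 1.4-fold lower number from compound 1 to compound 3 (0.16 log units; within the scatter), swapped one such ring for another and changed little. The expected change is a 1.9-fold higher number from compound 3 to compound 4 (0.28 log units; within the scatter), a modest move toward a higher number with wide uncertainty. Compound 4 is estimated at 450 nM, with a range of 120 nM to 1700 nM.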

Compound 4, inhibition constant: 536 nM
Compound 4: middle estimate off by 1.2-fold (0.08 log units), on the low side; the measured number falls inside the stated range.
By their numbers in this assay, from the lowest: compound 2; then compounds 3, 1 and 4 (each within the scatter of the next, the first and the last beyond it).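

In this assay the five-membered aromatic ring on the saturated chain carbon bound to a sulfur can give way to hydroxycarbamoyl, which has no ring, with only a modest shift: a 2.3-fold higher number from compound 3 to compound 4 (0.36 log units; beyond the scatter) and a 1.6-fold higher number from compound 1 to compound 4 (0.20 log units; within the scatter) are both far from a loss of binding. The first step lies beyond the scatter and the second within it, so the open-chain group is only partly separated from the two ring-bearing compounds. Nothing measured offers an explanation for this shift.

From the compounds shown here alone, whether a carboxylic acid, an amine or a longer chain at this place would behave like hydroxycarbamoyl remains open. Also open, going by these compounds, is whether the same replacement holds with the group of compound 2, methyl in place of cyclopropyl on the saturated chain carbon bound to an oxygen on an aromatic ring.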